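The compounds below may be only part of what the source reports. "The series", "measured", "known", "first", "only" and "open" are said of these compounds alone.

The compounds measured so far in a functional assay on A549 cells (Homo sapiens) for cytotoxicity, read by MTT assay, with a stated time of 72 h; a higher number here means a weaker inhibitor, a lower number a stronger inhibitor:

Compound 1, `CNC(=O)c1cc(Oc2ccc(NC(=O)c3nn(-c4ccccc4OC(F)(F)F)c(=O)cc3C)cc2F)ccn1`, gives > 40000 nM, which is a limit of the assay and not a number.
Compound 2, `CNC(=O)c1cc(Oc2ccc(NC(=O)c3nn(-c4cccc(F)c4)c(=O)cc3C)cc2F)ccn1`, gives 9540 nM.
Compound 3, `Cc1cc(=O)n(-c2ccccc2OC(F)(F)F)nc1C(=O)Nc1ccc(Oc2ncnc3sccc23)cc1`, gives 15500 nM.

Compound 1 and compound 2 share one core and differ in a single place: 3-fluorophenyl in place of 2-(trifluoromethoxy)phenyl on an aromatic nitrogen. That change gave an at least 4.1-fold lower number from compound 1 to compound 2 (0.62 log units; beyond the scatter). Compound 1 stands at the limit of > 40000 nM in this assay, at which 1 of the 3 values shown sits, so the step is told as a bound rather than a full number.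

Compound 3 is built on another core; the difference between the two cores of compound 1 and compound 3 is not broken down here. The values of compound 3 and compound 2 lie within the scatter of each other, so no order between them is read.

Compound 4, `Cc1cc(=O)n(-c2cccc(F)c2)nc1C(=O)Nc1ccc(Oc2ncnc3sccc23)cc1`, is not yet measured in this assay. It differs from compound 3 in one place: 3-fluorophenyl in place of 2-(trifluoromethoxy)phenyl on an aromatic nitrogen. The place of this change is described word for word as for the change from compound 1 to compound 2, so it is the same change carried onto the core of compound 3.

For compound 4 the expected step is a 3.9-fold lower number from compound 3 to compound 4 (0.59 log units; beyond the scatter). This expectation rests on compound 2, which reached 9540 nM through an at least 4.1-fold lower number from compound 1 to compound 2 (0.62 log units; beyond the scatter), and on compound 3 sitting at 15500 nM. Compound 4 is therefore estimated at 4000 nM, expected to fall between 1500 nM and 12000 nM.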

Compound 4, half-maximal inhibitory concentration: 16400 nM
Estimate against measurement, compound 4: 4.1-fold (0.61 log units) below; the measured number lies above the stated range.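

In this assay, 3-fluorophenyl in place of 2-(trifluoromethoxy)phenyl on the aromatic nitrogen gave a 1.1-fold higher number from compound 3 to compound 4 (0.02 log units; within the scatter), so no order between these two compounds is read. The change therefore did not carry over from the core of compound 1 to the core of compound 3 with the same result, and the two steps differ: the same change on two cores in this assay, an at least 4.1-fold lower number (0.62 log units; beyond the scatter) from compound 1 to compound 2 and a 1.1-fold higher number (0.02 log units; within the scatter) from compound 3 to compound 4, at least 4.4-fold (0.64 log units) apart, beyond the scatter of two such steps. Compound 1 gives > 40000 nM, which is a limit of the assay and not a number, so the earlier step is known only as a bound, and with a single pair on each core the comparison does not show why the same change gives different results on the two cores.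

The compounds shown leave open whether this difference between the cores is particular to these two groups or would also appear with other groups on the same aromatic nitrogen, such as an unsubstituted phenyl, a chlorophenyl or a phenyl carrying an amine. They also leave open how the change would read on a third core, and whether the result on the core of compound 1 or that on the core of compound 3 is the more usual one.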